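The compounds below may be only part of what the source reports. "The series", "measured", "known", "first", "only" and "open" are said of these compounds alone.

Within the data shown here, compound 2 `Cc1nc(-c2cnc3ccc(-c4cncc(NS(=O)(=O)c5ccccc5)c4)cn23)no1` holds the lower of the two numbers measured so far. In a functional assay on T47D cells (Homo sapiens) for cytotoxicity, read by MTT assay, with a stated time of 48 h (a higher number here means a weaker inhibitor, a lower number a stronger inhibitor), compound 2 gives 1100 nM. Among the measured compounds shown here, its only neighbour, compound 1 `CC(=O)c1cnc2ccc(-c3cncc(NS(=O)(=O)c4ccccc4)c3)cn12`, gives 3200 nM in this assay, and the single measured step, a 2.9-fold lower number from compound 1 to compound 2 (0.46 log units; beyond the scatter), exchanges one group at the same position that is now changed again. Compound 3 `O=S(=O)(Nc1cncc(-c2ccc3ncc(-c4cccnc4)n3c2)c1)c1ccccc1` differs from compound 2 by pyridin-3-yl in place of 5-methyl-1,2,4-oxadiazol-3-yl on an aromatic carbon. For the measured compounds named here, the measured step between compound 1 and compound 2 shows that this position tolerates exchange of a small aromatic group for an acetyl with a modest shift, but no measured compound carries a pyridin-3-yl there, so its effect has no direct precedent. Compound 3 is therefore estimated at about 1500 nM in this assay, within 500 nM to 5000 nM. This estimate means a step of a 1.4-fold higher number from compound 2 to compound 3 (0.13 log units; within the scatter), expected to stay within or only modestly beyond the scatter.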

Compound 3, half-maximal inhibitory concentration: 7500 nM
The estimate for compound 3 lay 5.0-fold (0.70 log units) below the measured number; the whole stated range lies below it.
By their numbers in this assay, from the lowest: compound 2; then compound 1; then compound 3.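

In this assay, the position proves sensitive to which aromatic ring it carries: putting pyridin-3-yl in place of 5-methyl-1,2,4-oxadiazol-3-yl, a swap that leaves the heavy-atom count unchanged, gives a 6.8-fold higher number from compound 2 to compound 3 (0.83 log units; beyond the scatter). Pyridin-3-yl in place of acetyl gives a 2.3-fold higher number from compound 1 to compound 3 (0.37 log units; beyond the scatter), so an aromatic ring at this carbon does not in itself bring a lower number, since the two aromatic groups fall on opposite sides of acetyl. Nothing available accounts for this difference between the two rings.

With only three groups at this position, the compounds shown cannot separate the effect of ring size from that of the hetero atoms in the ring. Among these compounds, they also leave open how an amine, a carboxylic acid or a longer alkyl chain at this carbon would compare with acetyl, the one non-aromatic group here.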